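The source may report more compounds than this note shows. Statements on the series, on what has been measured and on what is new or still open speak of the compounds shown alone.

Measured so far in a functional assay on A549 cells (Homo sapiens) for cytotoxicity, read by MTT assay, with a stated time of 72 h; a lower number here means a stronger inhibitor, a higher number a weaker inhibitor:
- compound 1 `O=C1c2c[n+]([O-])c3ccccc3c2C(=O)c2c1c1ccccc1n2CCCCn1ccnc1`: 170 nM
- compound 2 `CN1CCN(CCCCn2c3c(c4ccccc42)C(=O)c2c[n+]([O-])c4ccccc4c2C3=O)CC1`: 90 nM

Compound 2 stands level with compound 1 on these two numbers, with a 1.9-fold lower number from compound 1 to compound 2 (0.28 log units; within the scatter). Compound 3 `O=C1c2c[n+]([O-])c3ccccc3c2C(=O)c2c1c1ccccc1n2CCCCN1CCNCC1` differs from compound 2 as follows: hydrogen in place of methyl on an amine nitrogen in a ring. This puts hydrogen in place of methyl on an amine nitrogen in a ring. Among the compounds with values here, no measured step covers this exact change. The nearest evidence is the larger group exchange in a 1.9-fold lower number from compound 1 to compound 2 (0.28 log units; within the scatter), so no shift beyond the scatter is expected in this assay. The expected change is a 1.1-fold higher number from compound 2 to compound 3 (0.05 log units; within the scatter). Compound 3 is estimated at 100 nM, with an expected range of 40 nM to 250 nM.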

Compound 3, half-maximal inhibitory concentration: 540 nM
Compound 3: the middle estimate sits 5.4-fold (0.73 log units) below what was measured; measured number outside the range, above it.
By their numbers in this assay, from the lowest: compounds 2 and 1 (each within the scatter of the next); then compound 3.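

In this assay, this amine nitrogen in the ring responds to a single methyl: hydrogen in its place gives a shift beyond the scatter (a 6.0-fold higher number from compound 2 to compound 3 (0.78 log units; beyond the scatter)), a change the earlier exchange of end groups did not reveal. Piperazin-1-yl also separates from 1H-imidazol-1-yl on the same chain (a 3.2-fold higher number from compound 1 to compound 3 (0.50 log units; beyond the scatter)). Nothing available gives a reason for these shifts. Still open, going by these compounds, is whether an ethyl or acetyl group on this nitrogen would read like compound 2 or compound 3, and whether the methyl step holds on a shorter chain.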